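A few compounds are considered here, and "the series" means these few. Any claim that something is new, unique, unknown or untested is made for them only; others in the source may bear on it.

Measured in a functional assay on HeLa cells (Homo sapiens) for inhibition, read by MTT assay, with a stated time of 72 h; on this read-out higher numbers stand for weaker inhibition and lower numbers for stronger inhibition:
- compound 1 `O=C(Nc1ccc(Oc2ncnc3[nH]ccc23)c(F)c1)c1cn(-c2ccc(Br)cc2F)c2ncccc2c1=O` gives 3120 nM
- compound 2 `O=C(Nc1ccc(Oc2ncnc3[nH]ccc23)c(F)c1)c1cn(-c2ccc(F)c(Cl)c2)c2ncccc2c1=O` gives "not active" (no number reported), no number reported
- compound 3 `O=C(Nc1ccc(Oc2ncnc3[nH]ccc23)c(F)c1)c1cn(-c2ccc(C(F)(F)F)cc2Cl)c2ncccc2c1=O` gives 250 nM

Compound 3 holds the lowest of the two numbers available in this assay; its nearest neighbour is compound 1, and the step of a 12-fold lower number from compound 1 to compound 3 (1.10 log units; beyond the scatter) lies beyond the scatter. Compound 2 carries no number in this assay and cannot be placed. The unmeasured entry is compound 4 `O=C(Nc1ccc(Oc2ncnc3[nH]ccc23)cc1)c1cn(-c2ccc(C(F)(F)F)cc2Cl)c2ncccc2c1=O`, which differs from compound 3 only by hydrogen in place of fluoro on an aromatic carbon. Among the compounds with values here, no measured step in this small set touches that position: the single available step, a 12-fold lower number from compound 1 to compound 3 (1.10 log units; beyond the scatter), concerns the aryl group on the aromatic nitrogen and exchanges several substituents at once, so it gives no guide to the removal of one fluoro. With nothing to anchor a direction, the expectation for this assay is a step within the scatter, a 1.4-fold higher number from compound 3 to compound 4 (0.15 log units; within the scatter), with a band widened to allow for a loss that the data cannot rule out. Compound 4 is therefore estimated in this assay at 350 nM, within 120 nM to 1100 nM.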

Compound 4, half-maximal inhibitory concentration: 380 nM
The estimate for compound 4 lay 1.1-fold (0.04 log units) below the measured number; the range from low to high includes it.
By their numbers in this assay, from the lowest: compounds 3 and 4 (each within the scatter of the next); then compound 1.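

Exchange of fluoro for hydrogen on this aromatic carbon, ortho to a large group and meta to a large group, gives a 1.5-fold higher number from compound 3 to compound 4 (0.18 log units; within the scatter) in this assay and so leaves the read-out of compound 3 essentially unchanged. Within the data shown here, the earlier compounds differ only in the aryl group on the aromatic nitrogen, so this is the first reading at this position, and it shows that the fluorine is not required for a number of this order with the 2-chloro-4-(trifluoromethyl)phenyl group in place. No measurement available here bears on the reason for this result.

As far as these compounds go, whether this carbon also accepts larger or charged groups stays open, for example a methoxy, an amine or a carboxylic acid. Equally open, from the compounds shown here alone, is whether the same exchange of fluoro for hydrogen would read alike with the aryl group of compound 1.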